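Swapping fluoro for bromo in a poorly soluble series

This account rests on a few compounds, and the source may have more. Where it says the series, first, only, none or still open, it means among the compounds named here.

Compound 3 `CNC(=O)c1cc(Oc2ccc3nc(Nc4ccc(F)cc4)ncc3c2)ccn1` has been measured in a physicochemical assay for solubility, at pH 7 (on this read-out higher numbers stand for higher solubility and lower numbers for lower solubility), and compound 3 gives < 1000 nM, which is a limit of the assay rather than a number. Compound 1 `CNC(=O)c1cc(Oc2ccc3nc(Nc4ccccc4)ncc3c2)ccn1` shares the core and in this assay compound 1 gives < 1000 nM, again a limit. Compound 2 `CCc1ccccc1Nc1ncc2cc(Oc3ccnc(C(=O)NC)c3)ccc2n1` in this assay gives < 1000 nM, also a limit. All three values therefore sit together, as the limit of < 1000 nM in this assay, at which 3 of the 3 values shown sit, records. The three steps among them, a step that the two limits leave unreadable from compound 1 to compound 2, a step that the two limits leave unreadable from compound 1 to compound 3 and a step that the two limits leave unreadable from compound 2 to compound 3, give no readable size, so the numbers shown say nothing about how a change at this part of the molecule moves solubility.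

Compound 4 `CNC(=O)c1cc(Oc2ccc3nc(Nc4ccc(Br)cc4)ncc3c2)ccn1` differs from compound 3 by bromo in place of fluoro on an aromatic carbon. Within the data shown here, since no measured step in this assay can be read, nothing points to a move beyond the scatter, and the expected step is a step that the limit leaves unreadable from compound 3 to compound 4, with a limit again the most likely outcome. Compound 4 is therefore estimated at 500 nM, with a range from 100 nM to 1500 nM.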

Compound 4, solubility: < 1000 nM
Compound 4 ended at the assay's limit; the forecaster's own chance of this, stated with the estimate: 85%; the middle value is on the limit's open side.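

No step from compound 1, compound 2 or compound 3 to compound 4 can be read in this assay, because all four compounds rest at the same limit: the limit of < 1000 nM in this assay, at which 4 of the 4 values shown sit.

Still open, going by these compounds, is how soluble each compound really is, and whether bromo in place of fluoro changes that at all.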